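The source may report more compounds than this note shows. Statements on the series, on what has been measured and on what is new or still open speak of the compounds shown alone.

Measured so far in an in vitro assay on BL21-DE3 cells for displacement of a labelled ligand from thyroid hormone receptor beta (Homo sapiens), read by fluorescence polarization; on this read-out lower numbers stand for stronger inhibition and higher numbers for weaker inhibition:
compound 1 `CCCCCCc1ccc(C(=O)CCN(CCCC)CCCC)cc1` gives 4200 nM
compound 2 `C=CC(=O)c1ccc(CCC)cc1` gives 100000 nM

Compound 2 holds the highest number of the two; its nearest neighbour, compound 1, sits far lower, beyond the scatter. Going by the values given here, no single-point step between measured compounds is available. Compound 3 `C=CC(=O)c1ccc(CCCCCCCC)cc1` differs from compound 2 by pentyl in place of hydrogen on a saturated chain carbon, three bonds along the chain from an aromatic carbon, lengthening the saturated chain on the core of compound 2. Compound 1, which also carries a long chain on its aromatic ring, gives 4200 nM, so a lower number for compound 3 is expected. The step from compound 2 to compound 3 is estimated at a 5.0-fold lower number from compound 2 to compound 3 (0.70 log units; beyond the scatter), downward and beyond the scatter. Compound 3 is estimated at 20000 nM, within 5000 nM to 70000 nM.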

Compound 3, half-maximal inhibitory concentration: 11400 nM
The estimate for compound 3 lay 1.8-fold (0.24 log units) above the measured number; the measured number falls inside the stated range.
By their numbers in this assay, from the lowest: compound 1; then compound 3; then compound 2.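

In this assay the saturated chain proves responsive: pentyl in place of hydrogen on a saturated chain carbon, three bonds along the chain from an aromatic carbon, brings an 8.8-fold lower number from compound 2 to compound 3 (0.94 log units; beyond the scatter), a modest step beyond the scatter. This is the only step shown that changes one place, so the chain extension alone moves the number while the rest of the core stays fixed. No available evidence bears on the reason for this step.

Still open, from the compounds shown here alone, is whether a longer chain at this place lowers the number further or reverses the trend. Also open, going by these compounds, is what an amine adds on this core when the chain stays unchanged.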